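The source may report more compounds than this note shows. Statements on the series, on what has been measured and on what is new or still open speak of the compounds shown alone.

Measured compounds in a functional assay, read by spectrophotometry, with a stated time of 5 min; a lower number here means a stronger inhibitor, a higher number a weaker inhibitor:
compound 1 `O=c1[nH]c2ccccc2cc1/C=N/CCO` gives 467000 nM
compound 2 `N/N=C/c1cc2ccccc2[nH]c1=O` gives 184000 nM
compound 3 `Cc1ccc2[nH]c(=O)c(/C=N/CCO)cc2c1` gives 1480000 nM

Compound 1 stands second highest of the three numbers in this assay. The nearer neighbour lies at a 2.5-fold lower number from compound 1 to compound 2 (0.40 log units; beyond the scatter); the further one lies at a 3.2-fold higher number from compound 1 to compound 3 (0.50 log units; beyond the scatter). Both steps are modest, and both lie beyond the scatter.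

Compound 4 `O=c1[nH]c2ccccc2cc1/C=N/Cc1ccccc1` is not yet measured. It differs from compound 1 in one place: phenyl in place of hydroxymethyl on a saturated chain carbon bound to a double-bonded nitrogen.

For the measured compounds named here, only one measured step touches the same place, the substituent on the double-bonded nitrogen: there 2-hydroxyethyl was exchanged for amino, a different change from the one here, and it moved the number by a 2.5-fold lower number from compound 1 to compound 2 (0.40 log units; beyond the scatter). The other measured step concerns an aromatic carbon of the shared core and moved the number by a 3.2-fold higher number from compound 1 to compound 3 (0.50 log units; beyond the scatter); it says nothing about the chain end. Going by the values given here, there is thus no direct precedent for exchanging hydroxymethyl against phenyl. Since both changes seen so far moved this assay only modestly, the expectation for compound 4 is a step of similar size, leaning slightly toward a lower number, or none beyond the scatter: a 1.3-fold lower number from compound 1 to compound 4 (0.13 log units; within the scatter). Compound 4 is estimated at 350000 nM, with a range from 100000 nM to 1200000 nM.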

Compound 4, half-maximal inhibitory concentration: 329000 nM
Estimate against measurement, compound 4: 1.1-fold (0.03 log units) above, and the stated range covers the measured number.
By their numbers in this assay, from the lowest: compounds 2, 4 and 1 (each within the scatter of the next, the first and the last beyond it); then compound 3.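

In this assay, for the compounds shown here, the exchange gives a 1.4-fold lower number from compound 1 to compound 4 (0.15 log units; within the scatter) for phenyl in place of hydroxymethyl on a saturated chain carbon bound to a double-bonded nitrogen, so the first change at the chain end itself stays within the scatter. Across compound 1 and compound 4, this position therefore accepts a group of 6 heavy atoms with one six-membered aromatic ring of carbon only in place of one of 2 heavy atoms, and the hydroxymethyl with its 1 hydrogen-bond donor and 1 hydrogen-bond acceptor is not needed to hold the number in this pair. No available measurement bears on why the number holds across this exchange.

The compounds shown leave open whether a basic amine or a carboxylic acid at the chain end, or a longer chain carrying the phenyl, would move the number beyond the scatter. They also leave open whether methyl on the aromatic carbon of the shared core would act on the phenyl compound as it does in the hydroxyethyl pair.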